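Dioxolanyl for methoxy on a fused aminopyridine core

This account rests on a few compounds, and the source may have more. Where it says the series, first, only, none or still open, it means among the compounds named here.

Measured in an assay on isolated protein for displacement of a labelled ligand from tyrosine-protein kinase TEC (Mus musculus), read by fluorescence polarization; on this read-out higher numbers stand for an effect only at larger amounts of compound and lower numbers for an effect already at smaller amounts:
compound 1, `Nc1ccc2c(n1)CCCC2`: 215000 nM
compound 2, `Nc1ccc2cc(Cl)ccc2n1`: 76000 nM
compound 3, `COc1ccc2nc(N)ccc2c1`: 63000 nM

Compound 3 gives the lowest of the three numbers, though its gap to compound 2 lies within the scatter, while compound 1 stands clearly higher. Compound 4, `Nc1ccc2cc(C3OCCO3)ccc2n1`, carries the change (1,3-dioxolan-2-yl in place of methoxy on an aromatic carbon). Going by the values given here, the only measured step at this carbon, a 1.2-fold lower number from compound 2 to compound 3 (0.08 log units; within the scatter), was within the scatter, so a swap of this group has so far left the number unmoved. The account therefore expects no step beyond the scatter in this assay , and compound 4 is estimated at 70000 nM with a range from 25000 nM to 200000 nM, an expected step of a 1.1-fold higher number from compound 3 to compound 4 (0.05 log units; within the scatter).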

Compound 4, half-maximal effective concentration: 34000 nM
Compound 4: middle estimate off by 2.1-fold (0.31 log units), on the high side; low and high end bracket the measured number.
By their numbers in this assay, from the lowest: compounds 4, 3 and 2 (each within the scatter of the next, the first and the last beyond it); then compound 1.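

In this assay the step of a 1.9-fold lower number from compound 3 to compound 4 (0.27 log units; within the scatter) shows that this aromatic carbon can carry a ring, the 1,3-dioxolan-2-yl group, without the number rising. Set against chloro, the same group gives the first step at this carbon that passes the scatter, a 2.2-fold lower number from compound 2 to compound 4 (0.35 log units; beyond the scatter) and a modest one. No evidence accompanies these numbers to explain them. As far as these compounds go, whether an amine, a carboxylic acid or a longer ether chain at this carbon would move the number further remains open. So does whether 1,3-dioxolan-2-yl would act the same way on the core of compound 1.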